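This account rests on a few compounds, and the source may have more. Where it says the series, first, only, none or still open, it means among the compounds named here.

Working notes on the lactam amide series. In a functional assay on MGC-803 cells (Homo sapiens) for antiproliferative activity, read by MTT assay, with a stated time of 72 h (on this read-out lower numbers stand for stronger inhibition and higher numbers for weaker inhibition), compound 1 `O=C(COc1ccc(C(=O)/C=C/c2ccc(F)c(F)c2)cc1)N[C@H]1CCOC1=O` gives > 64000 nM, a limit of the assay rather than a number. Compound 2 `CC(C)c1ccc(NCC(=O)N[C@H]2CCOC2=O)cc1` likewise reaches only the limit > 64000 nM in this assay. Compound 3 `Cc1cc(Cl)ccc1NCC(=O)N[C@H]1CCOC1=O` also sits at the limit > 64000 nM in this assay. Among the measured compounds shown here, compound 1 thus stands at the limit of > 64000 nM in this assay, at which 3 of the 3 values shown sit, with no measured step among the three to draw on. Compound 4 `O=C(COc1ccc(C(=O)/C=C/c2cccc(F)c2)cc1)N[C@H]1CCOC1=O` differs from compound 1 by hydrogen in place of fluoro on an aromatic carbon. No change beyond the usual scatter of this assay is expected in the step from compound 1 to compound 4, since compound 1 itself stops at the limit > 64000 nM. Compound 4 is therefore estimated at 64000 nM in this assay, within 30000 nM to 130000 nM, most likely as a limit, the step being a number no higher from compound 1 to compound 4 (the limit leaves the size open).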

Compound 4, half-maximal inhibitory concentration: > 64000 nM
Compound 4: no number, only a limit; the forecaster's own chance of this, stated with the estimate: 80%; the middle value sits exactly at the limit.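

Compound 1 and compound 4 both stop at a limit of the assay, so no step between them can be read: the limit of > 64000 nM in this assay, at which 4 of the 4 values shown sit.

The compounds shown leave open what the change from 3,4-difluorophenyl to 3-fluorophenyl does in this assay, and whether any of them gives a number there.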